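This account rests on a few compounds, and the source may have more. Where it says the series, first, only, none or still open, it means among the compounds named here.

Of the compounds shown here, three sharing one core have been measured in a functional assay on BJAB cells (Homo sapiens) for antiproliferative activity, with a stated time of 4 days; a higher number here means that more compound is needed for the effect, a lower number that less compound is needed. Compound 1 `Cc1ccc(-c2c(C)nn(-c3nc(-c4ccc(Cl)c(Cl)c4)c(SC(C)C)s3)c2C(=O)O)cc1` gives 3800 nM, compound 2 `Cc1nn(-c2nc(-c3ccc(Cl)c(Cl)c3)c(SC(C)C)s2)c(C(=O)O)c1-c1cccc(F)c1` gives 900 nM, and compound 3 `COc1cccc(-c2c(C)nn(-c3nc(-c4ccc(Cl)c(Cl)c4)c(SC(C)C)s3)c2C(=O)O)c1` gives 14000 nM. Compound 3 thus stands highest of the three: the nearest number is that of compound 1, a step of a 3.7-fold higher number from compound 1 to compound 3 (0.57 log units; beyond the scatter), and the furthest is that of compound 2, a step of a 16-fold higher number from compound 2 to compound 3 (1.19 log units; beyond the scatter). Both steps changed the group on the phenyl ring attached to the core, the second replacing fluoro with methoxy.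

Compound 4 `COc1cc(Cl)cc(-c2c(C)nn(-c3nc(-c4ccc(Cl)c(Cl)c4)c(SC(C)C)s3)c2C(=O)O)c1` differs from compound 3 by chloro in place of hydrogen on an aromatic carbon, on an aromatic carbon of a six-membered aromatic ring of carbon only, meta to a large group and meta to a methoxy group. Among the measured compounds shown here, no measured step adds a chloro to this ring, so neither measured step bears directly on it; the measured steps only show that substituents on this ring move this assay by modest to large amounts. A step of a 1.8-fold lower number from compound 3 to compound 4 (0.24 log units; within the scatter) is therefore expected, with wide uncertainty. Compound 4 is estimated at 8000 nM, in the range 2500 nM to 30000 nM.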

Compound 4, half-maximal effective concentration: 760 nM
Beside the measured number, compound 4's estimate is 11-fold (1.02 log units) above it, and the stated range ends above it.
By their numbers in this assay, from the lowest: compounds 4 and 2 (each within the scatter of the next); then compound 1; then compound 3.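

Adding chloro to the 3-methoxyphenyl group, at the place meta to a large group and meta to a methoxy group, produced an 18-fold lower number from compound 3 to compound 4 (1.27 log units; beyond the scatter) and shows that this single atom can move the number more than any group change among the earlier compounds did. The 3-chloro-5-methoxyphenyl group also reverses the standing of the methoxy series against the 4-methylphenyl group, with a 5.0-fold lower number from compound 1 to compound 4 (0.70 log units; beyond the scatter) and, against the 3-fluorophenyl group, a 1.2-fold lower number from compound 2 to compound 4 (0.07 log units; within the scatter) which leaves those two compounds level. Nothing at hand explains why one chloro has so large an effect.

Going by these compounds, whether the gain depends on the methoxy group remains open, since 3-chlorophenyl does not appear here. On these data alone, it is also open whether bromo, trifluoromethyl or an amine at this place would act as chloro does.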